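The compounds below may be only part of what the source reports. "The series", "measured", "known", "first", "only" and "open" are said of these compounds alone.

Measured so far:
Compound 1 `CC(C)[C@@H](NC(=O)c1ccc(F)cc1)C(=O)N1CCC(c2ccc(Cl)cc2)CC1` gives 118 nM in an assay on THP-1 cells for displacement of a labelled ligand from C-C chemokine receptor type 1 (Homo sapiens); a lower number here means a stronger inhibitor, a higher number a weaker inhibitor.
Compound 2 `CC(C)[C@@H](NC(=O)CCCc1ccccc1)C(=O)N1CCC(c2ccc(Cl)cc2)CC1` gives 95 nM in this assay.

Compound 2 shows the lowest of the two numbers in this assay, but its nearest neighbour is compound 1, and the step of a 1.2-fold lower number from compound 1 to compound 2 (0.09 log units; within the scatter) lies within the scatter, so the two cannot be ranked against each other. Compound 3 `CC(C)[C@@H](NC(=O)NCc1ccccc1)C(=O)N1CCC(c2ccc(Cl)cc2)CC1` is not yet measured. It differs from compound 2 by benzylamino in place of 3-phenylpropyl on a carbonyl carbon. Within the data shown here, only one measured step touches this region of the molecule, a 1.2-fold lower number from compound 1 to compound 2 (0.09 log units; within the scatter), and it exchanged one group on the carbonyl carbon for another without moving the number beyond the scatter. That step does not involve a benzylamino group, so it gives no direct guide; it only shows that the carbonyl substituent tolerated one exchange. Compound 3 is therefore expected to give a number close to compound 2, with the step of a 1.4-fold higher number from compound 2 to compound 3 (0.14 log units; within the scatter) estimated to lie within or near the scatter. The estimate for compound 3 is 130 nM with a range from 40 nM to 450 nM.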

Compound 3, half-maximal inhibitory concentration: 180 nM
The estimate for compound 3 lay 1.4-fold (0.14 log units) below the measured number; low and high end bracket the measured number.
By their numbers in this assay, from the lowest: compounds 2, 1 and 3 (each within the scatter of the next).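

In this assay, benzylamino on a carbonyl carbon is a third group at this position, after 4-fluorophenyl and 3-phenylpropyl, and the steps of a 1.9-fold higher number from compound 2 to compound 3 (0.28 log units; within the scatter) and a 1.5-fold higher number from compound 1 to compound 3 (0.18 log units; within the scatter) both lie within the scatter. The position therefore accepts a group that brings a nitrogen and a hydrogen-bond donor, which neither earlier group has, and the three compounds cannot be ranked against each other. No evidence is available to explain these numbers.

The compounds shown leave open whether any group on this carbonyl carbon, such as a carboxylic acid, a simple amine or a longer chain, would move the number beyond the scatter. They also leave open how the number responds to changes elsewhere on the shared core.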